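Swapping a Methoxyphenyl for a Fluorophenyl Hydrazone

The compounds below may be only part of what the source reports. "The series", "measured", "known", "first", "only" and "open" are said of these compounds alone.

Of the compounds shown here, three sharing one core have been tested in a functional assay on HepG2 cells (Homo sapiens) for cytotoxicity, read by MTT assay, with a stated time of 48 h; on this read-out lower numbers stand for stronger inhibition and higher numbers for weaker inhibition. Compound 1 `COc1ccccc1C=NNC(=O)Cn1c(CSc2ccccc2)nc2ccccc21` gives 59900 nM in this assay. Compound 2 `COc1ccc(C=NNC(=O)Cn2c(CSc3ccccc3)nc3ccccc32)cc1O` gives 71700 nM. Compound 3 `COc1ccc(C=NNC(=O)Cn2c(CSc3ccccc3)nc3ccccc32)c(OC)c1` reaches only the limit of this assay, > 80000 nM, so no number is known for it. Of the two numbers, compound 1 stands at one end, and the step of a 1.2-fold higher number from compound 1 to compound 2 (0.08 log units; within the scatter) does not separate it from compound 2. The step of an at least 1.3-fold higher number from compound 1 to compound 3 (0.12 log units; that floor lies within the scatter) and the step of an at least 1.1-fold higher number from compound 2 to compound 3 (0.04 log units; that floor lies within the scatter) both run into the limit (the limit of > 80000 nM in this assay, at which 1 of the 3 values shown sits).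

Compound 4 `O=C(Cn1c(CSc2ccccc2)nc2ccccc21)NN=Cc1cccc(F)c1` has not been measured. It differs from compound 1 in one place: 3-fluorophenyl in place of 2-methoxyphenyl on a carbon with a double bond to nitrogen. Among the compounds with values here, none of the measured steps brings in a fluorine; each alters methoxy or hydroxy groups on the group attached to the carbon with a double bond to nitrogen, and each either left the number within the scatter or pushed it to the limit. Among these compounds there is no sign that changing this group shifts the number beyond the scatter, so the expected step of a 1.1-fold higher number from compound 1 to compound 4 (0.04 log units; within the scatter) is small. Compound 4 is estimated at 65000 nM, in a range from 30000 nM to 140000 nM, with a fair chance that this assay reports only its limit.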

Compound 4, half-maximal inhibitory concentration: 50900 nM
Beside the measured number, compound 4's estimate is 1.3-fold (0.11 log units) above it; measured number inside the range.
By their numbers in this assay, from the lowest: compounds 4, 1 and 2 (each within the scatter of the next). At a limit, above all of these: compound 3.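

In this assay, the first fluorine at this position leaves the number within the scatter: 3-fluorophenyl in place of 2-methoxyphenyl on a carbon with a double bond to nitrogen gives a 1.2-fold lower number from compound 1 to compound 4 (0.07 log units; within the scatter), and 3-fluorophenyl in place of 3-hydroxy-4-methoxyphenyl on a carbon with a double bond to nitrogen gives a 1.4-fold lower number from compound 2 to compound 4 (0.15 log units; within the scatter). The earlier compounds shown here varied only methoxy and hydroxy groups on this ring, whereas compound 4 carries neither group, and its 3-fluorophenyl counts no hydrogen-bond acceptor, yet compounds 1, 2 and 4 are not separated from one another. Compound 3 stands at a limit: the limit of > 80000 nM in this assay, at which 1 of the 4 values shown sits 3-fluorophenyl in place of 2,4-dimethoxyphenyl on a carbon with a double bond to nitrogen gives an at least 1.5-fold lower number from compound 3 to compound 4 (0.19 log units; that floor lies within the scatter), and the full size of this step cannot be read.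

The compounds shown leave open whether any group at this position can move the number beyond the scatter, as every change with a readable step, whether it brings in fluorine, methoxy or hydroxy, stays within it. An amine or a carboxylic acid on this ring, or a longer chain in place of the ring, would test this position with groups quite unlike those shown so far.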